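A Chloro-to-Methyl Swap on Two Related Cores

This account rests on a few compounds, and the source may have more. Where it says the series, first, only, none or still open, it means among the compounds named here.

Compound 1 `C=C1C[C@]23C[C@@]1(O)CC[C@H]2c1ccc(OS(=O)(=O)c2ccc(C)cc2)c(C)c1[C@@H]3Cn1cc(-c2ccc(Cl)cc2)nn1`: in a functional assay on SMMC-7721 cells (Homo sapiens) for cytotoxicity, read by MTT assay, with a stated time of 4 days (a lower number here means a stronger inhibitor, a higher number a weaker inhibitor), compound 1 gives > 20000 nM, which is a limit of the assay rather than a number.
Compound 2 `C=C1C[C@]23C[C@@]1(O)CC[C@H]2c1ccc(OS(=O)(=O)c2ccc(C)cc2)c(C)c1[C@@H]3Cn1cc(-c2ccc(C)cc2)nn1`: compound 2 gives > 20000 nM, again a limit of the assay.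
Compound 3 `C=C1C(=O)[C@]23C[C@@]1(O)CC[C@H]2c1ccc(O)c(C)c1[C@@H]3Cn1cc(-c2ccc(Cl)cc2)nn1`: compound 3 gives 670 nM.

Compounds 1 and 2 differ in one place, (methyl in place of chloro on an aromatic carbon). The step that the two limits leave unreadable from compound 1 to compound 2 cannot be sized, since both compounds sit at the limit of > 20000 nM in this assay, at which 2 of the 3 values shown sit. Compound 3 carries a different core from compound 1; the difference between the two cores is not broken down here.

Compound 4 `C=C1C(=O)[C@]23C[C@@]1(O)CC[C@H]2c1ccc(O)c(C)c1[C@@H]3Cn1cc(-c2ccc(C)cc2)nn1` is not yet measured. It stands to compound 3 as compound 2 stands to compound 1: methyl in place of chloro on an aromatic carbon. The place of the change is the same word for word in both pairs, so this is the same change, made on the core of compound 3.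

The step from compound 3 to compound 4 is expected to be small, a 1.2-fold higher number from compound 3 to compound 4 (0.08 log units; within the scatter), because a step that the two limits leave unreadable from compound 1 to compound 2 gives no readable size and the change exchanges one heavy atom for one heavy atom without adding donors or acceptors. Compound 4 is therefore estimated at 800 nM, most likely between 300 nM and 2500 nM.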

Compound 4, half-maximal inhibitory concentration: 920 nM
Compound 4: the middle estimate sits 1.2-fold (0.06 log units) below what was measured; low and high end bracket the measured number.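

On the core of compound 3, replacing 4-chlorophenyl with 4-methylphenyl gives a 1.4-fold higher number from compound 3 to compound 4 (0.14 log units; within the scatter) in this assay, so on this core the readout does not tell the two groups apart. The same change on the core of compound 1 cannot be read, since compound 1 and compound 2 both give only a limit of the assay, not a number: the limit of > 20000 nM in this assay, at which 2 of the 4 values shown sit. Among the compounds shown here, this shows that methyl can stand in place of chloro on one core with no step beyond the scatter, but it does not show that the change behaves the same way on both cores, as only one of the two steps has a readable size.

The compounds shown carry only chloro or methyl at this place, so it remains open how a group such as an amine or a carboxylic acid would read there. It also remains open which of the places where the two cores differ accounts for the gap between their values.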